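The compounds below may be only part of what the source reports. "The series", "measured", "known", "first", "only" and "open" are said of these compounds alone.

Two measurements in an ADME assay for permeability, using PAMPA, at pH 7.4 (on this read-out lower numbers stand for lower permeability and higher numbers for higher permeability), frame this account, and compound 1 `Cc1[nH]c2ccccc2c(=O)c1Cc1ccccc1` gives 102 10^-6 cm/s there, the higher of the two numbers. In this assay compound 2 `Cc1[nH]c2ccc(F)cc2c(=O)c1Br` gives 18.3 10^-6 cm/s as its reading, and the gap between the two lies beyond the usual scatter. Going by the values given here, these two compounds do not differ in one place only, so the data hold no direct step between measured compounds and offer no measured precedent for the next change.

That change leads to compound 3 `Cc1[nH]c2ccc(Cl)cc2c(=O)c1Cc1ccccc1` which has not yet been measured. Its structure departs from compound 1 in a single place: chloro in place of hydrogen on an aromatic carbon with chloro in place of hydrogen on an aromatic carbon. Among the compounds with values here, with no measured step to draw on, no shift beyond the scatter is expected in either direction. The estimated step of a 1.2-fold lower number from compound 1 to compound 3 (0.08 log units; within the scatter) is therefore expected to remain within the scatter. Compound 3 is expected to read 85 10^-6 cm/s in this assay with an estimated range from 35 10^-6 cm/s to 190 10^-6 cm/s when the measurement is made.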

Compound 3, apparent permeability: 415 10^-6 cm/s
Compound 3: the middle estimate sits 4.9-fold (0.69 log units) below what was measured, and the stated range ends below it.
By their numbers in this assay, from the lowest: compound 2; then compound 1; then compound 3.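

In this assay, going by these compounds alone, chloro in place of hydrogen on an aromatic carbon gives a 4.1-fold higher number from compound 1 to compound 3 (0.61 log units; beyond the scatter), and this is the first step in the account that isolates a single change. The earlier compounds shown here could not show this, since compound 1 and compound 2 differ in more than one place; now a single chlorine atom, placed on the six-membered aromatic ring of carbon only, meta to a fused ring and para to a fused ring, is seen to carry the reading beyond the scatter and upward. Nothing available explains the size or the direction of this step.

As far as these compounds go, whether this step is particular to chloro remains open, since a single substitution cannot show how other groups at this same position, such as methoxy, nitrile, an amine or a carboxylic acid, would read in this assay. From the compounds shown here alone, it also remains open whether chloro in place of hydrogen at this position would give a comparable step on a parent compound other than compound 1, as this change has so far been seen only once.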